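Swapping one dimethylphenyl isomer for another on the shared core

The source may hold more compounds than are shown below. What is called first, only, known or untested is meant among the compounds shown, and "the series" means these compounds.

Measured so far in a functional assay on C8166 cells (Homo sapiens) for cytotoxicity, read by MTT assay; on this read-out higher numbers stand for lower toxicity in this test and lower numbers for higher toxicity in this test

Compound 1 `Cc1cc(S(N)(=O)=O)ccc1NC(=O)COc1ccc(Cl)cc1NC(=O)c1ccccc1C` gives 67300 nM
Compound 2 `COc1ccc(C(=O)Nc2cc(Cl)ccc2OCC(=O)Nc2ccc(S(N)(=O)=O)cc2C)cc1` gives 69500 nM
Compound 3 `Cc1ccc(C(=O)Nc2cc(Cl)ccc2OCC(=O)Nc2ccc(S(N)(=O)=O)cc2C)c(C)c1` gives 47600 nM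

Compound 3 at 47600 nM lies within the scatter of both other compounds, as a 1.4-fold lower number from compound 1 to compound 3 (0.15 log units; within the scatter) and a 1.5-fold lower number from compound 2 to compound 3 (0.16 log units; within the scatter) show. Compound 4 `Cc1cc(C)cc(C(=O)Nc2cc(Cl)ccc2OCC(=O)Nc2ccc(S(N)(=O)=O)cc2C)c1` differs from it by 3,5-dimethylphenyl in place of 2,4-dimethylphenyl on a carbonyl carbon in one place, with 3,5-dimethylphenyl in place of 2,4-dimethylphenyl on a carbonyl carbon. Among the measured compounds shown here, no measured step makes this exact change. The closest steps also alter the group on that carbonyl carbon: the two above and a 1.0-fold higher number from compound 1 to compound 2 (0.01 log units; within the scatter) all stay small. In this assay no step beyond the scatter is therefore expected. The expected step is a 1.2-fold higher number from compound 3 to compound 4 (0.06 log units; within the scatter) and nothing larger. The estimated value for compound 4 is 55000 nM (expected range 28000 nM to 100000 nM).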

Compound 4, half-maximal cytotoxic concentration: 36500 nM
Estimate against measurement, compound 4: 1.5-fold (0.18 log units) above, and the stated range covers the measured number.
By their numbers in this assay, from the lowest: compounds 4, 3, 1 and 2 (each within the scatter of the next).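

In this assay, 3,5-dimethylphenyl in place of 2,4-dimethylphenyl on the carbonyl carbon gives a step within the scatter, a 1.3-fold lower number from compound 3 to compound 4 (0.12 log units; within the scatter). The steps to the other two compounds, a 1.9-fold lower number from compound 2 to compound 4 (0.28 log units; within the scatter) and a 1.8-fold lower number from compound 1 to compound 4 (0.27 log units; within the scatter), also stay within it, so none of the four substituted phenyl groups shown at this position stands apart from the others. No measurement here offers an explanation for this result. On these data alone, whether a phenyl carrying a carboxylic acid or an amine on that carbonyl carbon would give a step beyond the scatter remains open.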